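Arylidene swap on the shared core: chloro to bromo

This account rests on a few compounds, and the source may have more. Where it says the series, first, only, none or still open, it means among the compounds named here.

Compound 1 `COc1ccc(C2C(C#N)=C(N)Oc3nc(Nc4ccc(S(N)(=O)=O)cc4)sc32)cc1` gives 14800 nM in a functional assay on MCF7 cells (Homo sapiens) for cytotoxicity, read by colony formation, with a stated time of 1 h; on this read-out higher numbers stand for weaker inhibition and lower numbers for stronger inhibition. Compound 2 `COc1ccc(C2C(C#N)=C(/N=C/c3ccc(Cl)cc3)Oc3nc(Nc4ccc(S(N)(=O)=O)cc4)sc32)cc1` gives 8720 nM in this assay, the lower of the two numbers, with compound 1 nearest; the step of a 1.7-fold lower number from compound 1 to compound 2 (0.23 log units; within the scatter) stays within the scatter. Compound 3 `COc1ccc(C2C(C#N)=C(/N=C/c3cccc(Br)c3)Oc3nc(Nc4ccc(S(N)(=O)=O)cc4)sc32)cc1` carries 3-bromophenyl in place of 4-chlorophenyl on a carbon with a double bond to nitrogen. For the measured compounds named here, no measured step moves one halogenated ring against another; the only nearby step is the one from compound 1 to compound 2, which was small. The step from compound 2 to compound 3 is therefore expected to be a 1.0-fold lower number from compound 2 to compound 3 (0.01 log units; within the scatter), not beyond the scatter. Compound 3 is estimated at 8500 nM, within 3000 nM to 25000 nM.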

Compound 3, half-maximal inhibitory concentration: 8720 nM
Compound 3: the middle estimate sits 1.0-fold (0.01 log units) below what was measured; the range from low to high includes it.
By their numbers in this assay, from the lowest: compounds 2, 3 and 1 (each within the scatter of the next).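

In this assay, 3-bromophenyl in place of 4-chlorophenyl on a carbon with a double bond to nitrogen gives no change at the digits printed from compound 2 to compound 3 (within the scatter), so this read-out does not separate these two halogenated rings. The second halogenated ring also stays within the scatter of the shared core carrying the free amine, with a 1.7-fold lower number from compound 1 to compound 3 (0.23 log units; within the scatter). No supporting data offer an explanation for this flat result.

Halogen and ring position differ together here. 3-chlorophenyl would be needed to separate them. From the compounds shown here alone, whether a carboxylic acid on the ring or a longer alkyl chain in its place moves the number beyond the scatter remains open.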